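A few compounds are considered here, and "the series" means these few. Any claim that something is new, unique, unknown or untested is made for them only; others in the source may bear on it.

Compound 1, `Nc1nc2cccc(OC(F)(F)F)c2s1`. In a functional assay on the whole organism with Rattus norvegicus as the target (a higher number here means that more compound is needed for the effect, a lower number that less compound is needed), compound 1 gives > 10 mg/kg, which is a limit of the assay and not a number.
Compound 2, `C=CCn1c(=N)sc2cc(OC(F)(F)F)ccc21`. In this assay compound 2 gives 7 mg/kg.
Compound 3, `CN(C)S(=O)(=O)CCn1c(=N)sc2cc(OC(F)(F)F)ccc21`. In this assay compound 3 gives > 10 mg/kg, again a limit of the assay and not a number.

Compound 3 therefore stands where the assay stops reporting numbers; the same holds for compound 1, as the limit of > 10 mg/kg in this assay, at which 2 of the 3 values shown sit, shows. Among the compounds with values here, only one measured step leads to compound 3, namely an at least 1.4-fold higher number from compound 2 to compound 3 (0.15 log units; that floor lies within the scatter), and its size rests on a limit, so it sets a floor only and that floor lies within the scatter.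

Compound 4, `C[S+]([O-])CCCn1c(=N)sc2cc(OC(F)(F)F)ccc21`, differs from compound 3 by a group of 4 heavy atoms (2 carbon, 1 oxygen, 1 sulfur; no ring) in place of a group of 6 heavy atoms (2 carbon, 1 nitrogen, 2 oxygen, 1 sulfur; no ring), on a saturated chain carbon, two bonds along the chain from an aromatic nitrogen. Within the data shown here, no measured pair exchanges one group for another at this place, so nothing measured bears directly on this change. Among the measured compounds shown here, the step that does touch this position, an at least 1.4-fold higher number from compound 2 to compound 3 (0.15 log units; that floor lies within the scatter), says only that the number did not fall clearly. The expectation for this assay is therefore no step beyond the scatter, in either direction.

Compound 4 is expected to give 10 mg/kg, with a range from 4 mg/kg to 25 mg/kg. The expected step of a number no higher from compound 3 to compound 4 (the limit leaves the size open) is an estimate only, and a limit rather than a number is about as likely as not.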

Compound 4, dose for half-maximal effect: 2.3 mg/kg
Compound 4: middle estimate off by 4.3-fold (0.64 log units), on the high side; measured number below the stated range.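

Within the data shown here, at the saturated chain carbon, two bonds along the chain from an aromatic nitrogen, the earlier compounds offered only a floor within the scatter, so they could not show that this part of the side chain matters in this assay. Replacing the dimethylsulfamoyl group now gives an at least 4.3-fold lower number from compound 3 to compound 4 (0.63 log units; beyond the scatter), and the comparison with the vinyl-bearing side chain gives a 3.0-fold lower number from compound 2 to compound 4 (0.48 log units; beyond the scatter), so the side chain of compound 4 requires less compound than either of the other two, and both differences clear the scatter. The first of these sizes remains a floor and its true size stays unknown, since one end of it is a limit of the assay and not a number: the limit of > 10 mg/kg in this assay, at which 2 of the 4 values shown sit.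

The compounds shown do not separate the effect of the sulfur-bearing end group from that of the chain carrying it, as both differ from compound 3 to compound 4. On these data alone, whether a sulfone, a sulfide, an amine or a longer chain at this place would give a number as low as that of compound 4 stays open.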